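Methyl in Place of Chloro: Estimating Compound 4

This account rests on a few compounds, and the source may have more. Where it says the series, first, only, none or still open, it means among the compounds named here.

Of the compounds shown here, three have been measured in a functional assay on HCT-116 cells (Homo sapiens) for cytotoxicity, read by MTT assay, with a stated time of 72 h; on this read-out lower numbers stand for stronger inhibition and higher numbers for weaker inhibition. Compound 1 `COc1cc2nc(Cc3ccc(Cl)cc3)[nH]c(=O)c2cc1OC` gives 9000 nM. Compound 2 `COc1cc2nc(-c3ccccc3Cl)nc(N=[N+]=[N-])c2cc1OC` gives 8000 nM, and compound 3 `COc1cc2nc(-c3cccc(Cl)c3)nc(N=[N+]=[N-])c2cc1OC` gives 10000 nM. Compound 3 has the highest of the three numbers, yet its gaps to compound 1 and to compound 2 both lie within the scatter, so no order among the three can be drawn. Among the compounds with values here, the only single-point step among the measured compounds is a 1.3-fold higher number from compound 2 to compound 3 (0.10 log units; within the scatter), a relocation of the chloro on the phenyl that left the number essentially where it was.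

Compound 4 `COc1cc2nc(-c3cccc(C)c3)nc(N=[N+]=[N-])c2cc1OC` differs from compound 3 by methyl in place of chloro on an aromatic carbon, sitting meta to a large group. Within the data shown here, no measured step exchanges chloro for methyl, so there is no direct precedent; the one available step, from compound 2 to compound 3, was within the scatter. The expected step is therefore no change at the digits printed from compound 3 to compound 4 (within the scatter), nothing beyond the scatter. Compound 4 is estimated in this assay at 10000 nM, within 4000 nM to 25000 nM.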

Compound 4, half-maximal inhibitory concentration: 9000 nM
Estimate against measurement, compound 4: 1.1-fold (0.05 log units) above, and the stated range covers the measured number.
By their numbers in this assay, from the lowest: compounds 2, 1, 4 and 3 (each within the scatter of the next).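

In this assay, methyl in place of chloro on this aromatic carbon, meta to a large group, gives a 1.1-fold lower number from compound 3 to compound 4 (0.05 log units; within the scatter) and so does not separate the two groups at this position. Set against the 2-chlorophenyl compound, the 3-methylphenyl group gives a 1.1-fold higher number from compound 2 to compound 4 (0.05 log units; within the scatter) and adds a second step that stays inside the scatter. No measured property bears on these steps, so nothing can be said about what lies behind them.

The compounds shown leave open whether an amine, a carboxylic acid or a longer chain at this place would give a number beyond the scatter of compound 3 and compound 4. They also leave open whether this position can move the number in this assay at all, as every step shown here stays within the scatter.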